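Anilinothiazolyl chalcones in a prostate cancer cell growth assay

This account rests on a few compounds, and the source may have more. Where it says the series, first, only, none or still open, it means among the compounds named here.

Compound 1 `Cc1nc(Nc2ccc(Cl)cc2)sc1C(=O)/C=C/c1ccccc1` — 24600 nM
Compound 2 `COc1cc(/C=C/C(=O)c2sc(Nc3ccc(Cl)c(Cl)c3)nc2C)cc(OC)c1OC` — 19300 nM
Compound 3 `Cc1ccc(Nc2nc(C)c(C(=O)/C=C/c3ccccc3Cl)s2)cc1` — > 25000 nM

In a functional assay on PC-3 cells (Homo sapiens) for cytotoxicity, read by MTT assay (on this read-out higher numbers stand for weaker inhibition and lower numbers for stronger inhibition), compound 2 gives 19300 nM, the lowest of the two numbers reported. Compound 1 sits nearest to it, and the gap between them is within the scatter of this assay, so no order can be read from it. For compound 3 only a limit is reported, (the limit of > 25000 nM in this assay, at which 1 of the 3 values shown sits).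

Compound 4 `COc1cc(/C=C/C(=O)c2sc(Nc3cccc(C)c3)nc2C)cc(OC)c1OC` has not yet been tested. It differs from compound 2 by 3-methylphenyl in place of 3,4-dichlorophenyl on a nitrogen on an aromatic ring. Within the data shown here, no measured pair isolates this change, so the expectation rests on the general run of the series, where every number is weak. Compound 4 is expected to stay near that level; the step of a 1.5-fold higher number from compound 2 to compound 4 (0.16 log units; within the scatter) is estimated as small, probably toward weaker inhibition or none beyond the scatter. The value expected for compound 4 is 28000 nM, within 12000 nM to 70000 nM.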

Compound 4, half-maximal inhibitory concentration: > 25000 nM
Compound 4 was reported as a limit; the forecaster's own chance of this, stated with the estimate: 50%; the middle value lies beyond the limit too.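

In this assay compound 4 is reported only as a limit, > 25000 nM. Setting 3-methylphenyl in place of 3,4-dichlorophenyl on a nitrogen on an aromatic ring gives an at least 1.2-fold higher number from compound 2 to compound 4 (0.11 log units; that floor lies within the scatter), so this pair shows no change beyond the scatter, though a larger one is not ruled out. The step has only a floor because compound 4 sits at the limit of the assay: the limit of > 25000 nM in this assay, at which 2 of the 4 values shown sit.

Going by these compounds, it remains open whether any other group at this place, such as a phenyl carrying a carboxylic acid or an amine, would give clearly stronger inhibition.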